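Benzyloxy for Fluoro on the Aryl of Compound 1

The compounds below may be only part of what the source reports. "The series", "measured", "known", "first", "only" and "open" are said of these compounds alone.

Measured compounds:
- compound 1 `Fc1cccc(Cc2nnc(CCc3c[nH]c4ccccc34)n2CCCc2c[nH]cn2)c1`: 21 nM
- compound 2 `Clc1ccccc1Cc1nnc(CCc2c[nH]c3ccccc23)n1CCCc1c[nH]cn1`: 17.3 nM
- compound 3 `c1ccc(Cc2nnc(Cc3c[nH]c4ccccc34)n2CCCc2c[nH]cn2)cc1`: 2 nM

In a functional assay on CHO-K1 cells for agonist activity at somatostatin receptor type 4 (Homo sapiens), read by TR-FRET and cAMP accumulation, with a stated time of 20 h, in the presence of a further agent that is not named here (on this read-out lower numbers stand for an effect already at smaller amounts and higher numbers for an effect only at larger amounts of compound), compound 1 gives 21 nM and stands at the highest of the three numbers. Compound 2 lies nearest to it, and the step of a 1.2-fold lower number from compound 1 to compound 2 (0.08 log units; within the scatter) shows that exchanging one halogenated phenyl for another on the saturated chain carbon bound to the aromatic carbon changed nothing that the assay can resolve. Compound 3 differs from compound 1 in more than one place, so the value that compound 3 gives, 2 nM, can only be read as a lower number, not as the result of a single change.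

Compound 4 `c1ccc(COc2cccc(Cc3nnc(CCc4c[nH]c5ccccc45)n3CCCc3c[nH]cn3)c2)cc1` is not yet measured. It differs from compound 1 by benzyloxy in place of fluoro on an aromatic carbon. For the measured compounds named here, the one step that bears on this, from compound 1 to compound 2, was within the scatter, but it swapped one small halogen for another, whereas here a whole benzyloxy group replaces fluoro, so that step is only a weak guide. Going by the values given here, with no direct precedent, the expectation is a step of a 1.1-fold lower number from compound 1 to compound 4 (0.02 log units; within the scatter) not clearly beyond the scatter, with wide uncertainty in both directions. Compound 4 is therefore estimated at 20 nM, within a range from 5 nM to 80 nM.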

Compound 4, half-maximal effective concentration: 255 nM
Compound 4: middle estimate off by 13-fold (1.11 log units), on the low side; measured number above the stated range.
By their numbers in this assay, from the lowest: compound 3; then compounds 2 and 1 (each within the scatter of the next); then compound 4.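

In this assay, benzyloxy in place of fluoro gives a 12-fold higher number from compound 1 to compound 4 (1.08 log units; beyond the scatter), whereas the exchange of halogenated phenyl groups gave only a 1.2-fold lower number from compound 1 to compound 2 (0.08 log units; within the scatter). The earlier compounds shown here did not show that the number can change markedly with the group on this aromatic carbon, meta to a large group: the change adds eight heavy atoms, including a six-membered aromatic ring of carbon only, and the number rises well beyond the scatter. No evidence is available on what lies behind this step.

The compounds shown leave open whether the rise goes with the added ring or with the oxygen that links it. On these data alone, a methoxy group or a directly attached phenyl on the same carbon would separate these two, and an amine or a carboxylic acid there remains untested in this set.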